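This account rests on a few compounds, and the source may have more. Where it says the series, first, only, none or still open, it means among the compounds named here.

Going by the values given here, compound 2 `CS(=O)(=NSC(F)(F)F)c1ccccc1` is the one compound with a numerical result here: in a functional assay on HepG2 cells (Homo sapiens) for cytotoxicity, read by MTT assay, with a stated time of 6 h (a higher number here means a weaker inhibitor, a lower number a stronger inhibitor), compound 2 gives 15 ug/mL. Compound 1 `O=S(=NSC(F)(F)F)(c1ccccc1)N1CCOCC1` is the other entry, and in this assay compound 1 shows "not determined" (no result reported), so nothing can be set beside compound 2. Compound 3 `CS(=O)(=NC(F)(F)F)c1ccccc1` has not been measured; it differs from compound 2 by trifluoromethyl in place of (trifluoromethyl)sulfanyl on a sulfonamide nitrogen. Among the compounds with values here, no step between two measured compounds is available, so the size of such a change cannot be read from any earlier pair; a shift no larger than the usual scatter is expected, in either direction. Compound 3 is therefore estimated at 20 ug/mL, with a range from 8 ug/mL to 50 ug/mL. That estimate corresponds to an expected 1.3-fold higher number from compound 2 to compound 3 (0.12 log units; within the scatter), within the scatter.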

Compound 3, half-maximal inhibitory concentration: > 200 ug/mL
Compound 3 was reported as a limit (the forecaster's own chance of this, stated with the estimate: 15%); middle value at least 10-fold (1.00 log units) from the limit.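

On a sulfonamide nitrogen, trifluoromethyl in place of (trifluoromethyl)sulfanyl proves far from neutral in this assay, giving an at least 13-fold higher number from compound 2 to compound 3 (1.12 log units; beyond the scatter). Going by these compounds alone, this is the first step that can be read at this position, and it shows that the group held there strongly shapes this read-out. The reading for compound 3 is a limit of the assay, not a number: the limit of > 200 ug/mL in this assay, at which 1 of the 3 values shown sits.

The compounds shown leave open whether the sulfur alone accounts for this step. A methylsulfanyl group or a plain methyl on that nitrogen would be needed to separate the sulfur from the trifluoromethyl.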